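Aryl amine substitution in the series: compound 2 to compound 3

A few compounds are considered here, and "the series" means these few. Any claim that something is new, unique, unknown or untested is made for them only; others in the source may bear on it.

Measured in a functional assay on A549 cells (Homo sapiens) for inhibition, read by MTT assay, with a stated time of 72 h; on this read-out higher numbers stand for weaker inhibition and lower numbers for stronger inhibition:
- compound 1 `Cc1ccccc1-c1cc(C(=O)N2CCC3(CC2)CC(=O)c2nn(C(C)(C)C)cc2O3)c2ccccc2n1`: 1880 nM
- compound 2 `CC(C)(C)n1cc2c(n1)C(=O)CC1(CCN(C(=O)c3cc(-c4ccc(N)cc4)nc4ccccc34)CC1)O2`: 970 nM

Of the two measured compounds, compound 2 at 970 nM stands within the scatter of compound 1, so this assay does not separate them. The next comparison is compound 3 `CN(C)c1ccc(-c2cc(C(=O)N3CCC4(CC3)CC(=O)c3nn(C(C)(C)C)cc3O4)c3ccccc3n2)cc1`, which has dimethylamino in place of amino on an aromatic carbon, turning 4-aminophenyl into 4-(dimethylamino)phenyl. For the measured compounds named here, only one measured step bears on this change: a 1.9-fold lower number from compound 1 to compound 2 (0.29 log units; within the scatter). That step exchanged 2-methylphenyl for the 4-aminophenyl now being altered, and it did not move the value beyond the scatter. Going by the values given here, no measured step covers substitution on the amino group itself, so the evidence is thin. The expected change is no larger than the scatter, with an estimated 1.0-fold higher number from compound 2 to compound 3 (0.01 log units; within the scatter). For compound 3 the expected value is 1000 nM, with an estimated range of 400 nM to 2500 nM.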

Compound 3, half-maximal inhibitory concentration: 1150 nM
Compound 3: the middle estimate sits 1.2-fold (0.06 log units) below what was measured; the range from low to high includes it.
By their numbers in this assay, from the lowest: compounds 2, 3 and 1 (each within the scatter of the next).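

In this assay, the amino group of the 4-aminophenyl can be exchanged for dimethylamino, which has no hydrogen-bond donor, with a 1.2-fold higher number from compound 2 to compound 3 (0.07 log units; within the scatter) as the step. For the compounds shown here, this is the first reading of a change on the amino group itself, and it stays within the scatter. The comparison with the 2-methylphenyl compound gives a 1.6-fold lower number from compound 1 to compound 3 (0.21 log units; within the scatter) and so, like the other steps, does not separate 2-methylphenyl, 4-aminophenyl and 4-(dimethylamino)phenyl on this read-out, while no measured evidence accounts for this flat picture.

Still open, on these data alone, is whether any group at this aromatic carbon gives a step beyond the scatter. A carboxylic acid, an acetamide or a longer amine chain in place of dimethylamino would test this.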